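The compounds below may be only part of what the source reports. "The series", "measured", "known", "first", "only" and "open" are said of these compounds alone.

Among the compounds with values here, in a functional assay on the whole organism (Hindlimb, strain albino) with Mus musculus as the target, in the maximal electroshock model, with a stated time of 0.5 h (a lower number here means that less compound is needed, a higher number that more compound is needed for the effect), compound 1 `COc1ccc(C2CC(Nc3nc4ccc(C)cc4s3)=NN2C(C)=O)cc1` gives 37.3 umol/kg and holds the lowest of the three numbers measured so far. In the same read-out compound 2 `COc1ccc(C2CC(Nc3nc4ccc([N+](=O)[O-])cc4s3)=NN2C(C)=O)cc1` gives 145 umol/kg and compound 3 `O=C(/C=C/c1ccc(Cl)cc1)Nc1nc2ccccc2s1` gives 367 umol/kg as the highest number, but compound 3 is not linked to compound 1 by a change in one place. Within the data shown here, the only measured step of that kind is modest and beyond the scatter (a 3.9-fold higher number from compound 1 to compound 2 (0.59 log units; beyond the scatter)), and it swaps methyl for nitro on an aromatic carbon, so it concerns a different part of the molecule.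

Compound 4 `CC(=O)N1N=C(Nc2nc3ccc(C)cc3s2)CC1c1ccc(O)cc1` keeps that methyl and changes elsewhere: hydrogen in place of methyl on an oxygen on an aromatic ring gives hydrogen in place of methyl on an oxygen on an aromatic ring, that is, methoxy to hydroxy. Among the measured compounds shown here, no measured pair carries this change, so the nitro step serves only as a gauge of size. Since compound 1 already sits lowest, a move to a higher number of similar or smaller size is expected, and a step within the scatter cannot be ruled out. The expected step is modest (a 1.7-fold higher number from compound 1 to compound 4 (0.24 log units; within the scatter)). The estimate for compound 4 is 65 umol/kg (expected range 25 umol/kg to 170 umol/kg).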

Compound 4, dose for half-maximal effect: 50.2 umol/kg
The estimate for compound 4 lay 1.3-fold (0.11 log units) above the measured number; low and high end bracket the measured number.
By their numbers in this assay, from the lowest: compounds 1 and 4 (each within the scatter of the next); then compound 2; then compound 3.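

In this assay, the 4-methoxyphenyl of compound 1 gives way to the 4-hydroxyphenyl of compound 4 with a 1.3-fold higher number from compound 1 to compound 4 (0.13 log units; within the scatter), so on this oxygen on an aromatic ring, hydrogen in place of methyl leaves a result that cannot be told apart from the scatter. Within the data shown here, until now the only single-place step was a 3.9-fold higher number from compound 1 to compound 2 (0.59 log units; beyond the scatter), with nitro in place of methyl on an aromatic carbon, which lies beyond the scatter; this is the first reading at the oxygen, and unlike that step it stays within the scatter. Nothing available gives a reason for this outcome.

The compounds shown leave open what a longer chain such as ethyl on this oxygen, or an amine in place of the hydroxy group, would do to the number in this assay. They also leave open whether methoxy to hydroxy would read the same with nitro on the other part of the molecule, as in compound 2, as this change is seen in one pair only.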